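Aryl ether in place of benzylamine on the shared core

The source may hold more compounds than are shown below. What is called first, only, known or untested is meant among the compounds shown, and "the series" means these compounds.

In a functional assay on A549 cells (Homo sapiens) for inhibition, read by sulforhodamine B assay, with a stated time of 48 h (on this read-out higher numbers stand for lower toxicity in this test and lower numbers for higher toxicity in this test), compound 3 `Nc1cc(N)c2nc(-c3ccccc3)c(NCc3ccc(F)cc3)nc2c1` gives 69200 nM. In this assay compound 1 `Nc1cc(N)c2nc(-c3ccccc3)c(NCc3ccc(Cl)c(Cl)c3)nc2c1` gives 69200 nM, and the step of no change at the digits printed from compound 1 to compound 3 (within the scatter) leaves compound 3 level with compound 1 at the digits shown. Compound 2 `COc1ccc(CNc2nc3cc(N)cc(N)c3nc2-c2ccccc2)cc1OC` is reported in this assay only as a limit, < 100000 nM. the limit of < 100000 nM in this assay, at which 1 of the 3 values shown sits, covers that entry. For the measured compounds named here, the steps a step that the limit leaves unreadable from compound 1 to compound 2 and a step that the limit leaves unreadable from compound 2 to compound 3 therefore give no readable size, and the only readable step in the set is the one from compound 1 to compound 3.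

Compound 4 `Nc1cc(N)c2nc(-c3ccccc3)c(Oc3ccc(F)cc3)nc2c1` differs from compound 3 by 4-fluorophenoxy in place of (4-fluorobenzyl)amino on an aromatic carbon. Going by the values given here, every measured step in the set changes the aryl ring carried on the saturated chain carbon bound to the ring nitrogen; none removes that chain or its nitrogen, so no measured step bears directly on the change from compound 3 to compound 4. Among the compounds with values here, the one readable step, no change at the digits printed from compound 1 to compound 3 (within the scatter), shows only that the aryl substitution pattern on the benzyl carbon leaves the read-out unchanged. With no comparison for the linker itself, the expectation is a step of no more than the scatter, a 1.0-fold lower number from compound 3 to compound 4 (0.00 log units; within the scatter), in either direction. Compound 4 is thus estimated at 69000 nM, expected to lie from 25000 nM to 100000 nM.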

Compound 4, concentration lethal to 50% of the cells: 89100 nM
For compound 4 the middle estimate is 1.3-fold (0.11 log units) below the measured one; measured number inside the range.
By their numbers in this assay, from the lowest: compounds 1, 3 and 4 (each within the scatter of the next).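

Placing 4-fluorophenoxy in place of (4-fluorobenzyl)amino on this aromatic carbon changes the link between the shared core and the aryl ring, not the ring's substituents, and in this assay this gives a 1.3-fold higher number from compound 3 to compound 4 (0.11 log units; within the scatter). In this pair, the saturated chain carbon and the hydrogen-bond donor of the leaving group can therefore both go without a step beyond the scatter, so the read-out at this position does not depend on either of them here. Nothing among the data shown accounts for this step, and no cause can be assigned to it.

Going by these compounds, this is a single pair carrying a 4-fluorophenyl ring, so it remains open whether the ether link would behave the same way with the 3,4-dichlorophenyl or 3,4-dimethoxyphenyl ring. Also open, on these data alone, is whether a sulfur link, an amide or a longer chain at this position, or a carboxylic acid on the aryl ring, would move the number beyond the scatter.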